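This account rests on a few compounds, and the source may have more. Where it says the series, first, only, none or still open, it means among the compounds named here.

Measured in a functional assay on HCT-8 cells (Homo sapiens) for antiproliferative activity, read by MTT assay, with a stated time of 48 h; on this read-out lower numbers stand for stronger inhibition and higher numbers for weaker inhibition:
- compound 1 `CNCC(=O)Nc1cc(OC)ccc1C(=O)c1ccc2c(c1)C=CC(C)(C)O2`: 1010 nM
- compound 2 `COc1ccc(C(=O)c2cc(OC)c(OC)c(OC)c2)c(NC(=O)CO)c1`: 120 nM
- compound 3 `C=C(c1ccc(OC)cc1NC(=O)CO)c1ccc(OC)c2c1OC(C)(C)C=C2`: 130 nM

The number for compound 3 lies within the usual scatter of that for compound 2, and clearly below that for compound 1. Compound 4 `C=C(c1ccc(OC)cc1NC(=O)CNC)c1ccc(OC)c2c1OC(C)(C)C=C2` differs from compound 3 in one place: methylamino in place of hydroxy on a saturated chain carbon bound to a carbonyl carbon. Within the data shown here, no measured pair shows this swap alone. Compound 1 also carries methylamino on such a chain, on a different core, and compound 1 gives 1010 nM, so a modest weakening is expected in this assay. The expected change is a 2.3-fold higher number from compound 3 to compound 4 (0.36 log units; beyond the scatter). The estimate for compound 4 is 300 nM, with an expected range of 100 nM to 900 nM.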

Compound 4, half-maximal inhibitory concentration: 320 nM
Estimate against measurement, compound 4: 1.1-fold (0.03 log units) below; the measured number falls inside the stated range.
By their numbers in this assay, from the lowest: compounds 2 and 3 (each within the scatter of the next); then compound 4; then compound 1.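

In this assay, among these compounds, the change to methylamino in place of hydroxy on a saturated chain carbon bound to a carbonyl carbon gives a 2.5-fold higher number from compound 3 to compound 4 (0.39 log units; beyond the scatter) and this is the first direct reading of that swap on one core. The step is modest, so this place accepts methylamino with only a limited loss of activity, while hydroxy remains the better of the two groups here. The data offer no explanation for this step.

Going by these compounds, whether a primary amino group, dimethylamino or a longer chain would do better or worse at this place stays open. So does whether the same swap would give a similar step on the core of compound 2.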